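Compound 2 Gives Way to a 5-Methylthiophen-2-yl Analogue

The source may hold more compounds than are shown below. What is called first, only, known or untested is meant among the compounds shown, and "the series" means these compounds.

Going by the values given here, in a functional assay on MCF7 cells (Homo sapiens) for cytotoxicity, read by MTT assay, with a stated time of 48 h (a higher number here means a weaker inhibitor, a lower number a stronger inhibitor), compound 1 `COc1ccc(/C=C2/S/C(=N/c3ccccc3)N(Cc3ccncc3)C2=O)cc1OC` gives 80700 nM, while compound 2 `CCOc1cc(/C=C2/S/C(=N/c3ccccc3)N(Cc3ccncc3)C2=O)ccc1O` gives 20100 nM, the lower of the two numbers measured so far. Compound 3 `Cc1ccc(/C=C2/S/C(=N/c3ccccc3)N(Cc3ccncc3)C2=O)s1` carries 5-methylthiophen-2-yl in place of 3-ethoxy-4-hydroxyphenyl on a double-bonded chain carbon bound to a double-bonded ring carbon. Among the compounds with values here, only one measured step bears on this place: a 4.0-fold lower number from compound 1 to compound 2 (0.60 log units; beyond the scatter), a modest change beyond the scatter. Within the data shown here, no five-membered ring has yet been measured here, so this guide is thin and the margin must stay wide. Leaving the group that gave the lower number, a modest rise is expected in this assay. The estimated change is a 2.0-fold higher number from compound 2 to compound 3 (0.30 log units; within the scatter), towards a weaker inhibitor. For compound 3 the expected value is 40000 nM, with an estimated range of 12000 nM to 130000 nM.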

Compound 3, half-maximal inhibitory concentration: 28700 nM
Estimate against measurement, compound 3: 1.4-fold (0.14 log units) above, and the stated range covers the measured number.
By their numbers in this assay, from the lowest: compounds 2 and 3 (each within the scatter of the next); then compound 1.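

In this assay, the step of a 1.4-fold higher number from compound 2 to compound 3 (0.15 log units; within the scatter) shows that this place on a double-bonded chain carbon bound to a double-bonded ring carbon takes a five-membered aromatic ring with 1 hetero atom in place of a six-membered aromatic ring of carbon only, with the two compounds remaining indistinguishable. The step of a 2.8-fold lower number from compound 1 to compound 3 (0.45 log units; beyond the scatter) shows that 5-methylthiophen-2-yl also stands clear of 3,4-dimethoxyphenyl, and since compound 3 has 0 hydrogen-bond donors, a hydrogen-bond donor on this group is not required to reach the level of compound 2. Nothing available gives a reason for these numbers.

On these data alone, what the methyl of 5-methylthiophen-2-yl contributes remains open, as does the effect of an amine or a carboxylic acid on that ring. The rest of the shared core stays unchanged across the compounds shown, so what other parts contribute is also open.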